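The source may hold more compounds than are shown below. What is called first, only, known or untested is meant among the compounds shown, and "the series" means these compounds.

Measured so far, in an assay on isolated protein for binding affinity to 5-hydroxytryptamine receptor 3A (Homo sapiens); a higher number here means a weaker inhibitor, a lower number a stronger inhibitor:

Compound 1, `Clc1ccccc1-c1n[nH]cc1N1CCNCC1`: > 10000 nM
Compound 2, `Clc1cccc(-c2n[nH]cc2N2CCNCC2)c1`: 806 nM
Compound 3, `Fc1ccccc1-c1n[nH]cc1N1CCNCC1`: 1960 nM

The value for compound 1 is a limit of this assay, not a number, as the limit of > 10000 nM in this assay, at which 1 of the 3 values shown sits, records. Compound 1 and compound 3 share the core and differ only by fluoro in place of chloro on an aromatic carbon; that change gave an at least 5.1-fold lower number from compound 1 to compound 3 (0.70 log units; beyond the scatter). Compound 2 is built from the same atoms as compound 1, joined differently; how the two cores differ is not broken down here. Among the numbers given, compound 2 stands lowest, and compound 3 is its nearest neighbour.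

Compound 4, `Fc1cccc(-c2n[nH]cc2N2CCNCC2)c1`, is not yet measured. It differs from compound 2 by fluoro in place of chloro on an aromatic carbon, the same kind of change as from compound 1 to compound 3, though there the place was ortho to a large group and here it is meta to a large group. The earlier step rests on a limit for compound 1, so its size is only a lower bound, and it says nothing direct about a fluoro placed meta. With compound 2 at 806 nM as the starting point, the step from compound 2 to compound 4 in this assay is expected to be a 1.3-fold lower number from compound 2 to compound 4 (0.13 log units; within the scatter), smaller than the earlier one. The value expected for compound 4 is 600 nM, within 200 nM to 2000 nM.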

Compound 4, inhibition constant: > 10000 nM
Compound 4: no number, only a limit; the forecaster's own chance of this, stated with the estimate: 3%; middle value at least 16-fold (1.22 log units) from the limit.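

In this assay, fluoro in place of chloro on an aromatic carbon, here meta to a large group, gave an at least 12-fold higher number from compound 2 to compound 4 (1.09 log units; beyond the scatter), so the change does not carry from the core of compound 1 to the core of compound 2 with its direction kept: the same change on two cores in this assay, an at least 5.1-fold lower number (0.70 log units; beyond the scatter) from compound 1 to compound 3 and an at least 12-fold higher number (1.09 log units; beyond the scatter) from compound 2 to compound 4, at least 63-fold (1.80 log units) apart, beyond the scatter of two such steps

The value of compound 4, > 10000 nM, is a limit of this assay and not a number, and compound 1 also sits at a limit: the limit of > 10000 nM in this assay, at which 2 of the 4 values shown sit.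

Both steps are therefore bounds on one side only, and this single pair of cores shows that the change is not transferable here without giving its true size, a cause for the reversal, or a rule for other cores.

Left open is what a group other than these two halogens, such as methoxy, nitrile or an amine, would give on the six-membered aromatic ring of either core. Also open, from the compounds shown here alone, is how far past the limit compound 1 and compound 4 actually lie.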